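The source may hold more compounds than are shown below. What is called first, only, known or untested is meant among the compounds shown, and "the series" means these compounds.

Going by the values given here, compound 2 `N#Cc1ccc(S(=O)(=O)N2C[C@H](S(=O)(=O)c3ccc(Cl)cc3)[C@](O)(CO)C2)cn1` gives 631 nM in an assay on cells for antagonist activity at transient receptor potential cation channel subfamily V member 4 (Homo sapiens), read by FLIPR and calcium flux, with a stated time of 10 min (a higher number here means a weaker inhibitor, a lower number a stronger inhibitor), the higher of the two numbers measured so far. Among the compounds with values here, its nearest neighbour, compound 1 `N#Cc1ccc(S(=O)(=O)N2C[C@H](S(=O)(=O)c3ccc(Cl)cc3)[C@](O)(CO)C2)c(Cl)c1`, gives 3.2 nM in this assay, and the single measured step, a 200-fold higher number from compound 1 to compound 2 (2.29 log units; beyond the scatter), shows how much the exchange of the aryl group on the sulfonyl sulfur costs. Compound 3 `N#Cc1ccc(S(=O)(=O)N2C[C@H](S(=O)(=O)c3ccc(Cl)cc3)[C@](O)(CO)C2)c(C(F)(F)F)n1` differs from compound 2 by trifluoromethyl in place of hydrogen on an aromatic carbon. Within the data shown here, no measured step tests a trifluoromethyl directly. Compound 1, however, carries a chlorine on the ring bound to that sulfonyl sulfur and is much stronger, and because of a 200-fold higher number from compound 1 to compound 2 (2.29 log units; beyond the scatter) a substituent on that ring, ortho to a large group, appears to matter. A partial return toward the number of compound 1 is therefore expected, so compound 3 is estimated at 40 nM, within a range from 6 nM to 250 nM. The expected step is a 16-fold lower number from compound 2 to compound 3 (1.20 log units; beyond the scatter).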

Compound 3, half-maximal inhibitory concentration: 20 nM
Estimate against measurement, compound 3: 2.0-fold (0.30 log units) above; the range from low to high includes it.
By their numbers in this assay, from the lowest: compound 1; then compound 3; then compound 2.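

In this assay, going by these compounds alone, the step of a 32-fold lower number from compound 2 to compound 3 (1.50 log units; beyond the scatter) is the first measured change at this aromatic carbon next to the ring nitrogen, and it shows that replacing the hydrogen there with trifluoromethyl gives a much stronger inhibitor. Only this one place differs, so the gain can be assigned to the exchange itself. The earlier step of a 200-fold higher number from compound 1 to compound 2 (2.29 log units; beyond the scatter) could not isolate this position, as it exchanged one whole aryl group for another.

From the compounds shown here alone, whether methyl, methoxy or an amine on the same carbon would also give a stronger inhibitor remains open, so it cannot yet be said how specific the gain is to trifluoromethyl. Nothing measured here explains why this exchange has so large an effect.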